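This account rests on a few compounds, and the source may have more. Where it says the series, first, only, none or still open, it means among the compounds named here.

Working notes on the series. Among the measured compounds shown here, compound 1 `Cc1nc(S(C)(=O)=O)ccc1Oc1ncnc(OC2CCN(C(=O)OC(C)C)CC2)c1F` is the reference point; in a functional assay on isolated protein for inhibition of Glucose-dependent insulinotropic receptor (Rattus norvegicus), read by HTRF and cAMP accumulation (on this read-out higher numbers stand for an effect only at larger amounts of compound and lower numbers for an effect already at smaller amounts), compound 1 gives 142 nM, the lowest of the two numbers measured so far. For the measured compounds named here, its only measured neighbour is compound 2 `Cc1nc(S(C)(=O)=O)ccc1Oc1ncnc(OC2CCN(C(=S)OC(C)C)CC2)c1F`, which in this assay gives 1050 nM; the step of a 7.4-fold higher number from compound 1 to compound 2 (0.87 log units; beyond the scatter) exchanges one group of six heavy atoms for another on the amine nitrogen in the ring and is the only measured change at this part of the molecule.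

Compound 3 `Cc1nc(S(C)(=O)=O)ccc1Oc1ncnc(OC2CCN(C(=O)C(C)(C)F)CC2)c1F` remains to be measured in this assay. Relative to compound 1 it carries 1-fluoro-1-methylethyl in place of isopropoxy on a carbonyl carbon, so the isopropoxycarbonyl becomes a (1-fluoro-1-methylethyl)carbonyl. The step from compound 1 to compound 2 is the only one that bears on this: it touches the same carbonyl-bearing substituent and shows that altering it moves the number beyond the scatter. Without a direct precedent for the entering group, a small loss is expected rather than a gain, a 1.8-fold higher number from compound 1 to compound 3 (0.26 log units; within the scatter). Compound 3 is therefore estimated at 260 nM in this assay, with a range from 80 nM to 850 nM.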

Compound 3, half-maximal effective concentration: 296 nM
Compound 3: middle estimate off by 1.1-fold (0.06 log units), on the low side; the range from low to high includes it.
By their numbers in this assay, from the lowest: compound 1; then compound 3; then compound 2.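

The isopropoxy group on the carbonyl carbon can be exchanged for 1-fluoro-1-methylethyl at only a modest cost in this assay, with a 2.1-fold higher number from compound 1 to compound 3 (0.32 log units; beyond the scatter), so the isopropoxy group is not indispensable for activity at this position, although compound 1 keeps the lowest number of the three. The exchange is also much less damaging than the change to compound 2, as the listed comparison of the two altered compounds shows a 3.5-fold lower number from compound 2 to compound 3 (0.55 log units; beyond the scatter), although compound 2 and compound 3 differ in the whole group on the amine nitrogen in the ring and not in one atom. No measurement is available that bears on the reason for either step.

The compounds shown do not separate the contribution of the fluorine from that of exchanging the isopropoxy oxygen for carbon, a question that a plain isopropyl group on the same carbonyl would address directly. On these data alone, how far this position tolerates other groups on the carbonyl, such as tert-butyl, cyclopropyl or trifluoromethyl, also remains open.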